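The compounds below may be only part of what the source reports. "The series", "measured", "known", "first", "only" and "open" are said of these compounds alone.

Measured compounds in an ADME assay on HaCaT cells (Homo sapiens) for antiproliferative activity, read by MTT assay, with a stated time of 48 h; a higher number here means a weaker inhibitor, a lower number a stronger inhibitor:
compound 1 `COc1ccc(-c2nn(-c3ccccc3)cc2C(=O)/C=C\Nc2ccc(Cl)cc2)cc1` gives 20900 nM.
compound 2 `COc1ccc(-c2nn(-c3ccccc3)cc2C(=O)/C=C\Nc2ccc(C(F)(F)F)cc2)cc1` gives > 50000 nM, which is a limit of the assay.
compound 3 `COc1ccc(-c2nn(-c3ccccc3)cc2C(=O)/C=C\Nc2ccc(O)cc2)cc1` gives 34600 nM.

Compound 3 holds the higher of the two numbers given; its nearest neighbour is compound 1 (a 1.7-fold higher number from compound 1 to compound 3 (0.22 log units; within the scatter)). Compound 4 `COc1ccc(N/C=C\C(=O)c2cn(-c3ccccc3)nc2-c2ccc(OC)cc2)cc1` differs from compound 3 by methyl in place of hydrogen on an oxygen on an aromatic ring. Among the measured compounds shown here, no measured step touches this oxygen; the known steps swap whole groups on the same aromatic ring: an at least 2.3-fold higher number from compound 1 to compound 2 (0.37 log units; beyond the scatter), a 1.7-fold higher number from compound 1 to compound 3 (0.22 log units; within the scatter), an at least 1.4-fold lower number from compound 2 to compound 3 (0.15 log units; that floor lies within the scatter). For the measured compounds named here, only the step to compound 2 lies beyond the scatter, and it ends at the assay limit (the limit of > 50000 nM in this assay, at which 1 of the 3 values shown sits). None of these bears directly on a hydroxy-to-methoxy change, so the expected step of a 1.2-fold lower number from compound 3 to compound 4 (0.06 log units; within the scatter) is small, without clear direction. Compound 4 is therefore estimated at 30000 nM, range 12000 nM to 70000 nM.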

Compound 4, half-maximal inhibitory concentration: > 50000 nM
Compound 4 was reported as a limit; the forecaster's own chance of this, stated with the estimate: 30%; middle value at least 1.6-fold (0.22 log units) from the limit.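

In this assay compound 4 gives > 50000 nM, which is a limit of the assay. Methyl on the oxygen therefore reads only as a floor, an at least 1.4-fold higher number from compound 3 to compound 4 (0.15 log units; that floor lies within the scatter), while methoxy in place of chloro gives the firmer reading, an at least 2.3-fold higher number from compound 1 to compound 4 (0.37 log units; beyond the scatter), so methoxy, like trifluoromethyl, stands clearly apart from chloro at this place on the ring. The step between compound 2 and compound 4 cannot be read, and the assay ceiling now constrains much of the series: the limit of > 50000 nM in this assay, at which 2 of the 4 values shown sit.

From the compounds shown here alone, the true size of the hydroxy-to-methoxy step stays open. Going by these compounds, whether an amine or a carboxylic acid on this aromatic ring would fall near compound 1 or at the limit also stays open.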